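Ester variation in a small three-compound series

The source may hold more compounds than are shown below. What is called first, only, known or untested is meant among the compounds shown, and "the series" means these compounds.

Measured in a functional assay, read by spectrophotometry, with a stated time of 30 min; a higher number here means that more compound is needed for the effect, a lower number that less compound is needed:
Compound 1 `COc1cc(C2Oc3cc([C@H]4Oc5cc(O)cc(O)c5C(=O)[C@@H]4O)ccc3OC2COC(=O)c2ccc([N+](=O)[O-])cc2)ccc1O` gives > 300000 nM, which is a limit of the assay.
Compound 2 `COc1cc(C2Oc3cc([C@H]4Oc5cc(O)cc(O)c5C(=O)[C@@H]4O)ccc3OC2COC(=O)c2cccc(Cl)c2)ccc1O` gives 106000 nM.
Compound 3 `COc1cc(C2Oc3cc([C@H]4Oc5cc(O)cc(O)c5C(=O)[C@@H]4O)ccc3OC2COC(=O)/C=C/c2ccc(Cl)cc2)ccc1O` gives 87900 nM.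

Compound 3 holds the lowest of the two numbers, with compound 2 close by; the step of a 1.2-fold lower number from compound 2 to compound 3 (0.08 log units; within the scatter) does not separate them. Compound 4 `COc1cc(C2Oc3cc([C@H]4Oc5cc(O)cc(O)c5C(=O)[C@@H]4O)ccc3OC2COC(=O)c2ccc(OC)c(OC)c2)ccc1O` differs from compound 3 by 3,4-dimethoxyphenyl in place of 2-(4-chlorophenyl)ethenyl on a carbonyl carbon. The steps of an at least 2.8-fold lower number from compound 1 to compound 2 (0.45 log units; beyond the scatter) and an at least 3.4-fold lower number from compound 1 to compound 3 (0.53 log units; beyond the scatter) were both beyond the scatter, whereas the two esters built on a six-membered aromatic ring of carbon only sit together. Since the entering group is again such a ring, compound 4 is expected to land near compound 2. For compound 4 the estimate is 130000 nM, range 60000 nM to 300000 nM. The expected step is a 1.5-fold higher number from compound 3 to compound 4 (0.17 log units; within the scatter), near the scatter.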

Compound 4, half-maximal effective concentration: 77000 nM
Compound 4: middle estimate off by 1.7-fold (0.23 log units), on the high side, within the range that was stated.
By their numbers in this assay, from the lowest: compounds 4, 3 and 2 (each within the scatter of the next). At a limit, above all of these: compound 1.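

In this assay, the change at this position, on a carbonyl carbon, gives a 1.1-fold lower number from compound 3 to compound 4 (0.06 log units; within the scatter) and a 1.4-fold lower number from compound 2 to compound 4 (0.14 log units; within the scatter), so an ester ring bearing hydrogen-bond acceptors and no chlorine, with no double bond outside the ring, stays level with both chlorine-bearing esters. With an at least 3.8-fold lower number from compound 1 to compound 4 (0.59 log units; beyond the scatter) added, 4-nitrophenyl alone stands apart among these four esters. Compound 1 can be read only against a limit: the limit of > 300000 nM in this assay, at which 1 of the 4 values shown sits.

Going by these compounds, how far compound 1 lies from the others stays open. So does how an amine or a carboxylic acid would read in place of these aromatic groups.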